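Hydroxy on the benzylamine side in a fluorinated core

The source may hold more compounds than are shown below. What is called first, only, known or untested is meant among the compounds shown, and "the series" means these compounds.

Compound 1 `N=C(NCc1ccccc1)[C@@H]1CCC(=O)N1Cc1ccccc1` is the parent of the set; in a functional assay on SH-SY5Y cells (Homo sapiens) for cytotoxicity, read by MTT assay, with stated times of 8 h, 30 min and 12 h, tested at 0.05 uM (on this read-out lower numbers stand for a weaker effect and higher numbers for a stronger effect at the one concentration tested), compound 1 gives 16.6%. Compound 2 `N=C(NCc1ccc(O)cc1)[C@@H]1CCC(=O)N1Cc1ccccc1` carries hydroxy in place of hydrogen on an aromatic carbon; in this assay compound 2 gives 19.8%, a step of a number 3.2 percentage points higher from compound 1 to compound 2 (within the scatter). Compound 3 `N=C(NCc1ccccc1)[C@@H]1CCC(=O)N1Cc1ccc(F)cc1` differs from compound 1 by fluoro in place of hydrogen on an aromatic carbon, and in this assay compound 3 gives 13.3%, a step of a number 3.3 percentage points lower from compound 1 to compound 3 (within the scatter). Compound 4 `N=C(NCc1ccc(O)cc1)[C@@H]1CCC(=O)N1Cc1ccc(F)cc1` is not yet measured; it differs from compound 3 by hydroxy in place of hydrogen on an aromatic carbon, the same change that was made on the parent, here on the core that carries the fluoro group. Since the earlier step stayed within the scatter, for compound 4 the expected step of a number 3.2 percentage points higher from compound 3 to compound 4 (within the scatter) is set alongside a number 3.2 percentage points higher from compound 1 to compound 2 (within the scatter). Compound 4 is therefore estimated at 16.5% in this assay, with a range from 9% to 24%.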

Compound 4, a percentage reported as activity, at one concentration (the size of the read-out at that concentration, not a potency): 35.2%
For compound 4 the middle estimate is 18.7 percentage points below the measured one; the measured number lies above the stated range.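

In this assay, the hydroxy change does not carry over unchanged to the core bearing the fluoro group, where it gives a number 21.9 percentage points higher from compound 3 to compound 4 (beyond the scatter): the same change on two cores in this assay, a number 3.2 percentage points higher (within the scatter) from compound 1 to compound 2 and a number 21.9 percentage points higher (beyond the scatter) from compound 3 to compound 4, 18.7 percentage points apart, beyond the scatter of two such steps

Read the other way, the fluoro change gives a number 15.4 percentage points higher from compound 2 to compound 4 (beyond the scatter), so its outcome also depends on the core: the same change on two cores in this assay, a number 3.3 percentage points lower (within the scatter) from compound 1 to compound 3 and a number 15.4 percentage points higher (beyond the scatter) from compound 2 to compound 4, 18.7 percentage points apart, beyond the scatter of two such steps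

The two changes are therefore not additive in this one set of four compounds, but the set shows neither a cause nor whether the same holds for other groups.

Open, as far as these compounds go, is whether a methoxy group or an amine in place of the hydroxy would also give the higher number. Also open, from the compounds shown here alone, is whether chloro in place of the fluoro would do the same.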